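Working notes: aryl exchange at the substituted position

The source may report more compounds than this note shows. Statements on the series, on what has been measured and on what is new or still open speak of the compounds shown alone.

compound 1 `Cc1cc(C2CCC2)c(S(C)(=O)=O)cc1C(=O)N=C(N)N` — 8.2 nM
compound 2 `Cc1cc(-n2ccnc2C)c(S(C)(=O)=O)cc1C(=O)N=C(N)N` — 29 nM

Both numbers come from a functional assay for inhibition of sodium/hydrogen exchanger (Oryctolagus cuniculus); a higher number here means a weaker inhibitor, a lower number a stronger inhibitor. Compound 2 has the higher of the two numbers; its nearest neighbour is compound 1, with a 3.5-fold higher number from compound 1 to compound 2 (0.55 log units; beyond the scatter), so compound 2 is the weaker of the two measured inhibitors. Compound 3 `Cc1cc(Oc2cccnc2)c(S(C)(=O)=O)cc1C(=O)N=C(N)N` is the next member, and it differs from compound 2 only at the same position that was varied before: (pyridin-3-yl)oxy in place of 2-methyl-1H-imidazol-1-yl on an aromatic carbon. For the measured compounds named here, the single measured step, from compound 1 to compound 2, shows that a different group at this position shifts the number only modestly. Going by the values given here, no measured pair covers the entry of (pyridin-3-yl)oxy itself, so the direction is open. The step of a 1.5-fold lower number from compound 2 to compound 3 (0.16 log units; within the scatter) is therefore expected to stay small, with a number close to that of compound 2. Compound 3 is estimated at 20 nM, with a range of 7 nM to 60 nM.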

Compound 3, half-maximal inhibitory concentration: 8.8 nM
Compound 3: the middle estimate sits 2.3-fold (0.36 log units) above what was measured; the range from low to high includes it.
By their numbers in this assay, from the lowest: compounds 1 and 3 (each within the scatter of the next); then compound 2.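

In this assay the exchange of 2-methyl-1H-imidazol-1-yl for (pyridin-3-yl)oxy gives a 3.3-fold lower number from compound 2 to compound 3 (0.52 log units; beyond the scatter) at this position, so an aromatic ring in this place does not by itself go with the higher number of compound 2. Set against cyclobutyl, the same group gives a 1.1-fold higher number from compound 1 to compound 3 (0.03 log units; within the scatter) and the two groups cannot be told apart in this assay, which leaves 2-methyl-1H-imidazol-1-yl as the only one of the three that stands apart. No measurement available here bears on why these groups differ.

The compounds shown do not separate the effect of the oxygen link from that of the pyridine ring, as the two enter together. As far as these compounds go, how a phenoxy group, or an amine such as piperidin-1-yl, would read at this position remains open.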